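The source may report more compounds than this note shows. Statements on the series, on what has been measured and on what is new or still open speak of the compounds shown alone.

Going by the values given here, in a functional assay on MCF7 cells (Homo sapiens) for antiproliferative activity, read by MTT assay, with a stated time of 72 h (a lower number here means a stronger inhibitor, a higher number a weaker inhibitor), compound 1 `CCCCCC(=O)Oc1cc(C(=O)C2=C3OC(C)(C)[C@@H](CC=C(C)C)C[C@@]34C[C@@H](CC=C(C)C)C(C)(C)[C@H]3CCC(C)(C)O[C@]34OC2=O)ccc1O` gives 15500 nM, the only full number. Compound 2 `CCC(=O)Oc1cc(C(=O)C2=C3OC(C)(C)[C@@H](CC=C(C)C)C[C@@]34C[C@@H](CC=C(C)C)C(C)(C)[C@H]3CCC(C)(C)O[C@]34OC2=O)ccc1O` stands at a limit, > 20000 nM. Compound 3 `CCCCCC(=O)Oc1ccc(C(=O)C2=C3OC(C)(C)[C@@H](CC=C(C)C)C[C@@]34C[C@@H](CC=C(C)C)C(C)(C)[C@H]3CCC(C)(C)O[C@]34OC2=O)cc1OC(=O)CCCCC` differs from compound 1 by pentylcarbonyl in place of hydrogen on an oxygen on an aromatic ring. Among the compounds with values here, the sole measured step is an at least 1.2-fold higher number from compound 1 to compound 2 (0.11 log units; that floor lies within the scatter), which changes the ester chain and not this oxygen, and its floor lies within the scatter. In this assay no step beyond the scatter is therefore expected, and the expected change is a 1.2-fold higher number from compound 1 to compound 3 (0.06 log units; within the scatter). For compound 3 the estimated value is 18000 nM, with an expected range of 8000 nM to 40000 nM.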

Compound 3, half-maximal inhibitory concentration: 16600 nM
Compound 3: the middle estimate sits 1.1-fold (0.04 log units) above what was measured; the range from low to high includes it.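

In this assay, pentylcarbonyl on the oxygen on the aromatic ring gives a 1.1-fold higher number from compound 1 to compound 3 (0.03 log units; within the scatter). The free hydroxy group at this position is therefore not required for the value seen with compound 1, and a second pentylcarbonyl ester is tolerated there. The data shown give no measured reason for this result.

Still open, as far as these compounds go, is whether a longer chain, an amine or a carboxylic acid carried on this oxygen would leave the number unchanged. Also open, from the compounds shown here alone, is the effect of replacing both ester chains with free hydroxy groups.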